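The source may report more compounds than this note shows. Statements on the series, on what has been measured and on what is new or still open speak of the compounds shown alone.

Compound 1 `CCOC(=O)c1cc(-c2cccc(OCc3ccccc3)c2)on1` is one of three closely related esters examined in an ADME assay on Vero cells (Chlorocebus sabaeus) for cytotoxicity, with a stated time of 72 h; a lower number here means a stronger inhibitor, a higher number a weaker inhibitor. In this assay compound 1 gives only a limit, > 128000 nM. Compound 2 `CCOC(=O)c1cc(-c2cccc(OCc3cccc(Cl)c3)c2)on1` likewise gives only a limit, > 128000 nM. Compound 3 `CCOC(=O)c1cc(-c2cccc(OCc3ccccc3[N+](=O)[O-])c2)on1` also gives only a limit, > 128000 nM. The steps a step that the two limits leave unreadable from compound 1 to compound 2 and a step that the two limits leave unreadable from compound 1 to compound 3 are therefore not readable in size, and the limit of > 128000 nM in this assay, at which 3 of the 3 values shown sit, sets the ceiling at which every shown value sits. Compound 4 `CCOC(=O)c1ccc(COc2cccc(-c3cc(C(=O)OCC)no3)c2)cc1` differs from compound 1 by ethoxycarbonyl in place of hydrogen on an aromatic carbon. Among the measured compounds shown here, no measured step bears on this change, so only the common ceiling guides expectation. The step from compound 1 to compound 4 is expected to be a step that the limit leaves unreadable from compound 1 to compound 4, most likely ending again at a limit. Compound 4 is estimated to give 200000 nM, in the range 100000 nM to 500000 nM.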

Compound 4, half-maximal inhibitory concentration: > 128000 nM
Compound 4 ended at the assay's limit; the forecaster's own chance of this, stated with the estimate: 85%; the middle value is on the limit's open side.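

The step from compound 1 to compound 4 cannot be read in this assay, as both compounds end at a limit: the limit of > 128000 nM in this assay, at which 4 of the 4 values shown sit.

The compounds shown leave open how far compound 1, compound 2, compound 3 and compound 4 each lie from that limit.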